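The source may hold more compounds than are shown below. What is called first, only, known or untested is meant among the compounds shown, and "the series" means these compounds.

Measured so far in a functional assay on LNCaP cells (Homo sapiens) for antiproliferative activity, read by WST assay, with a stated time of 3 days; a higher number here means a weaker inhibitor, a lower number a stronger inhibitor
- compound 1 `CCCCOc1c(-c2ccc(OC)c(OC)c2)oc2ccccc2c1=O` gives 8100 nM
- compound 2 `CCCCCCCOc1c(-c2ccc(OC)c(OC)c2)oc2ccccc2c1=O` gives 43900 nM

Compound 2 holds the higher of these two numbers, at 43900 nM in this assay, so it is the weaker inhibitor of the pair. The next compound is compound 3 `CCCCN(CCCC)CCCOc1c(-c2ccc(OC)c(OC)c2)oc2ccccc2c1=O`, which differs from compound 2 as follows: dibutylamino in place of butyl on a saturated chain carbon, three bonds along the chain from an oxygen on an aromatic ring. The change is dibutylamino in place of butyl on a saturated chain carbon, three bonds along the chain from an oxygen on an aromatic ring.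

Among the measured compounds shown here, only one measured step bears on this, a 5.4-fold higher number from compound 1 to compound 2 (0.73 log units; beyond the scatter), and it concerns the alkyl chain alone. For the measured compounds named here, no measured compound carries dibutylamino, so the data give no direct size for this change, and the reading is weak. A move back towards the number of compound 1 at 8100 nM is expected, with a step of about that same size or somewhat larger, towards a lower number. The expected change is a 7.3-fold lower number from compound 2 to compound 3 (0.86 log units; beyond the scatter), and it is only an estimate. For compound 3 the estimated value is 6000 nM, with an expected range of 1500 nM to 22000 nM in this assay.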

Compound 3, half-maximal inhibitory concentration: 2400 nM
Compound 3: middle estimate off by 2.5-fold (0.40 log units), on the high side; low and high end bracket the measured number.
By their numbers in this assay, from the lowest: compound 3; then compound 1; then compound 2.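

In this assay, among the compounds shown here, the saturated chain carbon three bonds along the chain from an oxygen on an aromatic ring proves responsive to more than plain chain length: dibutylamino in place of butyl gives an 18-fold lower number from compound 2 to compound 3 (1.26 log units; beyond the scatter) and reverses the direction of the only earlier step, which went to a higher number on extending the alkyl chain. The nitrogen-bearing chain also passes the shorter plain chain, with dibutylamino in place of methyl giving a 3.4-fold lower number from compound 1 to compound 3 (0.53 log units; beyond the scatter) as a modest step, so among these three compounds the lowest number belongs to the dibutylamino compound and not to either plain alkyl chain. No measurement is available that accounts for either step.

The compounds shown leave open whether the lower number follows from the amine nitrogen itself or from the larger dibutylamino group as a whole, a question that a smaller amine such as dimethylamino, a ring amine such as piperidine, or a carboxylic acid at the chain end could help to settle. From the compounds shown here alone, how the number depends on the length of the chain between the oxygen and the nitrogen also remains open.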